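Methyl in place of methylamino, tested on two cores

The source may report more compounds than this note shows. Statements on the series, on what has been measured and on what is new or still open speak of the compounds shown alone.

Compound 1 `C#Cc1cn([C@@H]2O[C@H](CO)[C@@H](O)[C@H]2O)c2ncnc(C)c12` and compound 2 `C#Cc1cn([C@@H]2O[C@H](CO)[C@@H](O)[C@H]2O)c2ncnc(NC)c12` share one core and differ only in methyl in place of methylamino on an aromatic carbon. In a functional assay on CEM-DNR-bulk cells (Homo sapiens), read by MTT assay, with a stated time of 72 h (a lower number here means a stronger inhibitor, a higher number a weaker inhibitor), compound 1 gives 160 nM, and compound 2 gives 18500 nM. The step is a 120-fold lower number from compound 2 to compound 1 (2.06 log units; beyond the scatter).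

Compound 3 `CNc1ncnc2c1c(-c1ccsc1)cn2[C@@H]1O[C@H](CO)[C@@H](O)[C@H]1O` keeps the methylamino of compound 2 but carries a different core: thiophen-3-yl in place of ethynyl on an aromatic carbon. Compound 3 reaches only a limit of this assay, > 20000 nM. The step of an at least 1.0-fold higher number from compound 2 to compound 3 (0.03 log units; that floor lies within the scatter) thus sets only a floor, and the limit of > 20000 nM in this assay, at which 1 of the 3 values shown sits, marks where compound 3 sits.

Compound 4 `Cc1ncnc2c1c(-c1ccsc1)cn2[C@@H]1O[C@H](CO)[C@@H](O)[C@H]1O` is compound 3 with methyl in place of methylamino on an aromatic carbon. The description of the place coincides word for word with the change from compound 2 to compound 1, so this is the same change carried onto the second core. The expected step is an at least 40-fold lower number from compound 3 to compound 4 (1.60 log units; beyond the scatter), set beside a 120-fold lower number from compound 2 to compound 1 (2.06 log units; beyond the scatter), on which it rests. Because compound 3 stands only at a limit > 20000 nM, the starting point is uncertain and the estimate carries a wide range. Compound 4 is expected to give about 500 nM in this assay, between 120 nM and 6000 nM.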

Compound 4, half-maximal inhibitory concentration: 8560 nM
For compound 4 the middle estimate is 17-fold (1.23 log units) below the measured one; the measured number lies above the stated range.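

In this assay, methyl in place of methylamino lowers the number on the second core as well, with an at least 2.3-fold lower number from compound 3 to compound 4 (0.36 log units; beyond the scatter), so the direction seen on the first core carries over to this one pair. Thiophen-3-yl in place of ethynyl, read with methyl on the aromatic carbon, gives a 54-fold higher number from compound 1 to compound 4 (1.73 log units; beyond the scatter), but the size of that change with methylamino in place cannot be fixed, and the two readings of it stay unresolved: the same change on two cores in this assay, an at least 1.0-fold higher number (0.03 log units; that floor lies within the scatter) from compound 2 to compound 3 and a 54-fold higher number (1.73 log units; beyond the scatter) from compound 1 to compound 4; the limit leaves it open whether they differ Compound 3 stands only at a limit of this assay, so the data show a floor for the methyl step on the second core and do not show that the step keeps, or loses, the size it has on the first core: the same change on two cores in this assay, a 120-fold lower number (2.06 log units; beyond the scatter) from compound 2 to compound 1 and an at least 2.3-fold lower number (0.36 log units; beyond the scatter) from compound 3 to compound 4; the limit leaves it open whether they differ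

The compounds shown leave open how far the methyl step on the second core really reaches, and whether the same direction would hold with a group other than ethynyl or thiophen-3-yl on the core, such as a phenyl or a longer alkyne. They also leave open how other groups on the aromatic carbon that carries methyl or methylamino, such as an unsubstituted amino group, an ethyl or a chlorine, would read in this assay.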